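This account rests on a few compounds, and the source may have more. Where it says the series, first, only, none or still open, it means among the compounds named here.

Compound 1 `Cc1ccc(N/C(=N/O)c2ccc3occc3c2)cc1C`: > 30000 nM
Compound 2 `O/N=C(/NCc1ccccc1)c1ccc2occc2c1`: > 30000 nM

Both values come from an assay on isolated protein for inhibition of Indoleamine 2,3-dioxygenase 1 (Homo sapiens), read by spectrophotometry; a higher number here means a weaker inhibitor, a lower number a stronger inhibitor. The value of compound 2 is a limit of this assay, not a number. The value of compound 1 is likewise a limit. This is the limit of > 30000 nM in this assay, at which 2 of the 2 values shown sit, so compound 2 stands at the weak end of what this assay can report. Compound 3 `O/N=C(/NCC1CC1)c1ccc2occc2c1` differs from compound 2 by cyclopropyl in place of phenyl on a saturated chain carbon bound to an amine nitrogen. Among the measured compounds shown here, no measured step exists to judge this change against. No shift beyond the scatter is expected; the estimated step that the limit leaves unreadable from compound 2 to compound 3 means compound 3 stays near the limit. Compound 3 is expected to give 50000 nM, within a range from 10000 nM to 300000 nM.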

Compound 3, half-maximal inhibitory concentration: > 30000 nM
Compound 3 was reported as a limit (the forecaster's own chance of this, stated with the estimate: 85%); the middle value lies beyond the limit too.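

Among the compounds shown here, replacing phenyl with cyclopropyl gives no step that can be read between compound 2 and compound 3, because both results are limits rather than numbers: the limit of > 30000 nM in this assay, at which 3 of the 3 values shown sit. The compounds shown leave open which change, if any, would bring a value within measurable range.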